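Replacing the benzyl group of compound 1

The source may report more compounds than this note shows. Statements on the series, on what has been measured and on what is new or still open speak of the compounds shown alone.

Compound 1 `COc1ccc2c(c1)cc(-c1cc(OC)c(OC)c(OC)c1)n2Cc1ccc(OCc2ccccc2)cc1`: > 30000 nM
Compound 2 `COc1ccc2c(c1)c(Cc1ccc(OCc3ccccc3)cc1)c(-c1cc(OC)c(OC)c(OC)c1)n2Cc1ccc(OCc2ccccc2)cc1`: > 30000 nM

Both compounds were tested in a functional assay on PC-3 cells (Homo sapiens) for cytotoxicity, read by MTT assay, with a stated time of 24 h; on this read-out higher numbers stand for weaker inhibition and lower numbers for stronger inhibition. Compound 1 gives > 30000 nM, which is a limit of the assay and not a number. Compound 2 gives > 30000 nM, which is also a limit. Among the compounds with values here, the data so far therefore offer only (the limit of > 30000 nM in this assay, at which 2 of the 2 values shown sit), and no step between measured compounds is available to give a scale.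

Compound 3 `COc1ccc2c(c1)cc(-c1cc(OC)c(OC)c(OC)c1)n2Cc1ccc(OC(C)CN(C)C)cc1` keeps the core of compound 1 and differs in one place: 1-((dimethylamino)methyl)ethyl in place of benzyl on an oxygen on an aromatic ring. A 1-((dimethylamino)methyl)ethyl group stands in place of benzyl on an oxygen on an aromatic ring, so benzyloxy becomes 1-((dimethylamino)methyl)ethoxy.

Within the data shown here, with no measured step as a guide, the expectation in this assay is tentative. If compound 3 returns a number at all, it is expected on the side of stronger inhibition, and the change is expected to be modest. It may equally stay at the limit. The estimated step is an at least 3.0-fold lower number from compound 1 to compound 3 (0.47 log units; beyond the scatter). The expected value for compound 3 is 10000 nM, with an estimated range from 3000 nM to 30000 nM.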

Compound 3, half-maximal inhibitory concentration: 13300 nM
For compound 3 the middle estimate is 1.3-fold (0.12 log units) below the measured one, within the range that was stated.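

The change from benzyloxy to 1-((dimethylamino)methyl)ethoxy gives an at least 2.2-fold lower number from compound 1 to compound 3 (0.35 log units; beyond the scatter) in this assay, which shows that activity at this place, on an oxygen on an aromatic ring, responds to the group attached there. Compound 1 gives > 30000 nM, which is a limit of the assay and not a number, so the full size of the change cannot be read. Compound 3 is the only compound shown that gives a number, and the other two remain at the limit: the limit of > 30000 nM in this assay, at which 2 of the 3 values shown sit.

The change removes a six-membered aromatic ring of carbon only and brings in a nitrogen in one step, so the compounds shown cannot separate the loss of the ring from the arrival of the amine. A plain isopropyl group on the same oxygen would address the first, while a longer chain ending in the same dimethylamine, or a morpholine in its place, would show how far this position tolerates change.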